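Taking the phenyl off compound 1

The compounds below may be only part of what the source reports. "The series", "measured", "known", "first", "only" and "open" are said of these compounds alone.

In a functional assay on SF-295 cells (Homo sapiens) for antiproliferative activity, read by sulforhodamine B assay, with a stated time of 72 h (on this read-out lower numbers stand for stronger inhibition and higher numbers for weaker inhibition), compound 1 `S=C(NNc1nncc2ccccc12)Nc1ccccc1` gives 9.5 nM and compound 2 `COc1ccc(NC(=S)NNc2nncc3ccccc23)cc1` gives 7.2 nM, so the two sit level. Compound 3 `N#Cc1ccc(Nc2nncc3ccccc23)cc1` gives 0.32 nM, well under both and beyond the scatter. Compound 4 `NC(=S)NNc1nncc2ccccc12` carries hydrogen in place of phenyl on an amide-type nitrogen, the difference from compound 1 being (hydrogen in place of phenyl on an amide-type nitrogen). Among the compounds with values here, only one measured step bears on this phenyl: a 1.3-fold lower number from compound 1 to compound 2 (0.12 log units; within the scatter), with methoxy in place of hydrogen on an aromatic carbon. Within the data shown here, no measured step removes the ring, so the expectation is weakly held. A modest upward move is expected, a 1.6-fold higher number from compound 1 to compound 4 (0.20 log units; within the scatter). Compound 4 is estimated at 15 nM, with an expected range of 4 nM to 60 nM.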

Compound 4, half-maximal inhibitory concentration: 9.3 nM
Compound 4: middle estimate off by 1.6-fold (0.21 log units), on the high side; low and high end bracket the measured number.
By their numbers in this assay, from the lowest: compound 3; then compounds 2, 4 and 1 (each within the scatter of the next).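

In this assay the anilino to amino change gives a 1.0-fold lower number from compound 1 to compound 4 (0.01 log units; within the scatter) and so leaves the number within the scatter. The earlier step only decorated the phenyl with methoxy, whereas this one shows that compound 1 keeps its level without the ring on this amide-type nitrogen. No measurement offered here explains the result.

Still open, from the compounds shown here alone, is whether a methyl group or a longer chain on this nitrogen would sit level with hydrogen and phenyl. A carboxylic acid on the phenyl of compound 1 is equally untested among the compounds shown.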